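Indazole Swap on a Triarylethylene Acrylic Acid

The source may report more compounds than this note shows. Statements on the series, on what has been measured and on what is new or still open speak of the compounds shown alone.

Measured compounds:
Compound 1, `O=C(O)/C=C/c1ccc(/C(=C(/CCO)c2ccccc2)c2ccc3[nH]ncc3c2)cc1`, > 1000 nM
Compound 2, `CC/C(=C(/c1ccc(/C=C/C(=O)O)cc1)c1ccc2[nH]ncc2c1C)c1ccccc1`, 50 nM

For the measured compounds named here, in a functional assay on MCF7 cells (Homo sapiens) for cytotoxicity, read by CellTiter-Glo, with a stated time of 5 days (a higher number here means a weaker inhibitor, a lower number a stronger inhibitor), compound 2 gives 50 nM, the only full number in this set. Compound 1, `O=C(O)/C=C/c1ccc(/C(=C(/CCO)c2ccccc2)c2ccc3[nH]ncc3c2)cc1`, is reported only as a limit of this assay, > 1000 nM, and it sits at the limit of > 1000 nM in this assay, at which 1 of the 2 values shown sits. Going by the values given here, no step between two measured compounds that differ in one place is available, so compound 2 is the only anchor for what follows.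

Compound 3, `CC/C(=C(/c1ccc(/C=C/C(=O)O)cc1)c1cc2cn[nH]c2cc1F)c1ccccc1`, has not been measured in this assay. It differs from compound 2 by 6-fluoro-1H-indazol-5-yl in place of 4-methyl-1H-indazol-5-yl on a double-bonded chain carbon bound to an aromatic carbon and a double-bonded chain carbon. The remainder of the molecule, the acrylic acid bearing arene, the ethyl group and the phenyl ring on the double bond, is unchanged. Among the compounds with values here, with no measured step of this kind to draw on, the expected change from compound 2 to compound 3 is small, a modest loss at most, and may well fall within the usual scatter of repeated measurements; the expected step is a 1.6-fold higher number from compound 2 to compound 3 (0.20 log units; within the scatter). Compound 3 is therefore expected to give about 80 nM in this assay, within the range 25 nM to 300 nM.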

Compound 3, half-maximal inhibitory concentration: 47 nM
Beside the measured number, compound 3's estimate is 1.7-fold (0.23 log units) above it; measured number inside the range.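

In this assay, putting 6-fluoro-1H-indazol-5-yl in place of 4-methyl-1H-indazol-5-yl on a double-bonded chain carbon bound to an aromatic carbon and a double-bonded chain carbon gives a 1.1-fold lower number from compound 2 to compound 3 (0.03 log units; within the scatter). For the compounds shown here, compound 2 had been the only full number in the set, so it could not show whether the value depended on the methyl-bearing indazole; this pair shows that, on an otherwise unchanged molecule, the fluorine-bearing indazole cannot be told apart from it in this read-out. Nothing measured here offers a cause for this match between the two groups.

Compound 1 is known only as a limit of the assay, > 1000 nM, and it differs from compound 2 in more than one place, so it adds nothing to this comparison. As far as these compounds go, how an indazol-5-yl group carrying a methoxy group or an amine would read in this assay remains open, as does whether the fluorine-bearing and methyl-bearing indazoles would still match with the ethyl group replaced by a longer chain.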